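Swapping Phenyl for Fluoro on the Sulfonamide Ring

The source may hold more compounds than are shown below. What is called first, only, known or untested is meant among the compounds shown, and "the series" means these compounds.

Compound 1 `Cc1ccc(S(=O)(=O)N2CCN(c3ncc(/C=C/C(=O)NO)s3)CC2)cc1` and compound 2 `O=C(/C=C/c1cnc(N2CCN(S(=O)(=O)c3ccc(-c4ccccc4)cc3)CC2)s1)NO` share one core and differ only in the group carried on an aromatic carbon. In a functional assay on MCF7 cells (Homo sapiens) for antiproliferative activity (a higher number here means a weaker inhibitor of growth, a lower number a stronger inhibitor of growth), compound 1 gives 2000 nM, and compound 2 gives 1500 nM. Compound 2 has the lower of the two numbers, yet the step of a 1.3-fold lower number from compound 1 to compound 2 (0.12 log units; within the scatter) stays within the scatter, so the two cannot be ranked against each other. Compound 3 `O=C(/C=C/c1cnc(N2CCN(S(=O)(=O)c3ccc(F)cc3)CC2)s1)NO` is the next member of the series: fluoro in place of phenyl on an aromatic carbon. For the measured compounds named here, the only measured step that bears on this position is the exchange of methyl for phenyl, a 1.3-fold lower number from compound 1 to compound 2 (0.12 log units; within the scatter), and it was too small to count as a real change. Since a change at the same place moved the number so little, the step of a 1.3-fold higher number from compound 2 to compound 3 (0.12 log units; within the scatter) is also expected to remain within the scatter. Compound 3 is therefore estimated at 2000 nM, with a range from 800 nM to 5000 nM.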

Compound 3, concentration for 50% growth inhibition: 2500 nM
Compound 3: middle estimate off by 1.3-fold (0.10 log units), on the low side; the measured number falls inside the stated range.
By their numbers in this assay, from the lowest: compounds 2, 1 and 3 (each within the scatter of the next).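

In this assay, this change takes away a whole six-membered aromatic ring of carbon and leaves a single fluoro atom in its place (a 1.7-fold higher number from compound 2 to compound 3 (0.22 log units; within the scatter)), and even so large a cut in group size stays within the scatter. Fluoro in place of methyl gives the same kind of reading (a 1.3-fold higher number from compound 1 to compound 3 (0.10 log units; within the scatter)), so methyl, phenyl and fluoro cannot be ranked at this position, and across these three compounds the size of the group shows no readable link to the number. Nothing available explains this flat result.

On these data alone, whether any group at this place can move the number beyond the scatter remains open, for instance an amine, a carboxylic acid or a longer chain. These compounds also cannot tell whether changes elsewhere on the shared core would matter more.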